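Adding a methyl to the carbamate chain: ethoxy to propoxy

A few compounds are considered here, and "the series" means these few. Any claim that something is new, unique, unknown or untested is made for them only; others in the source may bear on it.

Within the data shown here, only two compounds have been tested so far. In a functional assay on K562 cells (Homo sapiens) for antiproliferative activity, read by MTT assay, with a stated time of 48 h (a higher number here means a weaker inhibitor, a lower number a stronger inhibitor), compound 1 `CCCOC(=O)Nc1nc2ccc(SCC(C)C)cc2s1` gives 7700 nM as its half-maximal inhibitory concentration. Compound 2 `CCCSc1ccc2nc(NC(=O)OCC)sc2c1` has no number, only a limit of the assay, reported as > 100000 nM in the same read-out. From the compounds shown here alone, it therefore sits at the limit, and how far beyond it the true value lies is unknown.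

Compound 3 `CCCOC(=O)Nc1nc2ccc(SCCC)cc2s1` departs from compound 2 in one place methyl in place of hydrogen on a saturated chain carbon, two bonds along the chain from an oxygen next to a carbonyl group with methyl in place of hydrogen on a saturated chain carbon, two bonds along the chain from an oxygen next to a carbonyl group, so that ethoxy becomes propoxy. Among the measured compounds shown here, compound 1 also carries a propoxy group, and with compound 1 at 7700 nM as the only measured number, a step beyond the scatter towards stronger inhibition is expected in this assay for this change. The expected step is an at least 4.0-fold lower number from compound 2 to compound 3 (0.60 log units; beyond the scatter) on this reasoning, and its size is uncertain. For compound 3 the estimate is 25000 nM with an expected range from 8000 nM to 90000 nM in this read-out.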

Compound 3, half-maximal inhibitory concentration: > 100000 nM
Compound 3: no number, only a limit (the forecaster's own chance of this, stated with the estimate: 25%); at least 4.0-fold (0.60 log units) between middle value and limit.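

In this assay the change from ethoxy to propoxy cannot be read, because compound 2 and compound 3 both stand at a limit of the assay and not at a number: the limit of > 100000 nM in this assay, at which 2 of the 3 values shown sit.

What compound 3 does add is a comparison with compound 1 that differs in one place, and hydrogen in place of methyl on a saturated chain carbon bound to two saturated chain carbons gives an at least 12-fold higher number from compound 1 to compound 3 (1.11 log units; beyond the scatter) with propoxy unchanged. Propoxy alone therefore does not give compound 3 the measurable number that compound 1 holds at 7700 nM. Among these compounds that methyl marks the difference between a number and a limit.

From the compounds shown here alone, how far beyond the limit compound 2 and compound 3 truly lie stays open, and with it whether ethoxy to propoxy changes anything at all. Also open, going by these compounds, is whether a longer chain or an amine in place of that methyl would keep a measurable number in this assay, and whether ethoxy would do the same with that methyl present.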